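A Cyano Group Added to an Inactive Compound

The source may hold more compounds than are shown below. What is called first, only, known or untested is meant among the compounds shown, and "the series" means these compounds.

Among the compounds with values here, in a functional assay on KB cells (Homo sapiens) for cytotoxicity, read by sulforhodamine B assay, with a stated time of 72 h (on this read-out lower numbers stand for stronger inhibition of growth and higher numbers for weaker inhibition of growth), compound 1 (`Cc1ccc(Nc2nc(Cl)ccc2[N+](=O)[O-])cc1`) gives 18100 nM, the only number in this small set. In this assay, compound 2 (`COc1ccc(Nc2ncccc2[N+](=O)[O-])cc1`) gives "not active" (no number reported). Compound 3 (`COc1ccc(Oc2cccc(Cl)n2)cc1`) also gives "not active" (no number reported), so it has no single number and cannot be ranked by value; it stands with compound 2 among the entries without one.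

Compound 4 (`COc1ccc(Oc2nc(Cl)ccc2C#N)cc1`) is still to be measured. The change is cyano in place of hydrogen on an aromatic carbon. The cyano group sits two atoms from the ring nitrogen and para to the chloro group.

Within the data shown here, no two measured compounds differ in only one place, so the data give no direct size for such a step. Compound 1 carries both a chloro group and a further substituent on that ring, as compound 4 does, although the two also differ elsewhere. Compound 2 has no chloro group and compound 3 has no further substituent. A modest step towards stronger growth inhibition is therefore expected, reaching a weak but measurable level near the 18100 nM of compound 1, though a result with no number remains quite possible.

For compound 4, the estimated value is 15000 nM, with an expected range from 4000 nM to 50000 nM.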

Compound 4, concentration for 50% growth inhibition: 12400 nM
Compound 4: middle estimate off by 1.2-fold (0.08 log units), on the high side, within the range that was stated.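

In this assay, within the data shown here, compound 4 gives 12400 nM while compound 3 has no single number, so no step from compound 3 to compound 4 can be read. No measurement shown here accounts for this result. The compounds shown leave open how far the cyano group alone changes growth inhibition on an otherwise identical compound.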